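A few compounds are considered here, and "the series" means these few. Any claim that something is new, unique, unknown or untested is made for them only; others in the source may bear on it.

Measured so far:
Compound 1, `CC(C)=CCOc1cc(Nc2nccc(C)n2)ccc1Cl`, < 200 nM
Compound 2, `CC(C)=CCOc1cccc(Nc2nccs2)c1`, 23000 nM
Compound 3, `CC(C)=CCOc1cc(Nc2ncccn2)ccc1C`, 78000 nM

The study looks at tolerance of these compounds in a functional assay on MT2 cells (Homo sapiens) for cytotoxicity; a higher number here means that more compound is tolerated, a lower number that less compound is tolerated. Compound 2 holds the lowest of the two numbers that were read as numbers; compound 3 gives 78000 nM, a higher number that sits beyond the scatter of repeated measurements. The entry for compound 1 is not a number but a limit of the assay (the limit of < 200 nM in this assay, at which 1 of the 3 values shown sits).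

The next step leads from compound 2 to compound 4, `CCc1ccc(Nc2nccs2)cc1OCC=C(C)C`, which is still to be measured in this assay. The structures differ in one place: ethyl in place of hydrogen on an aromatic carbon.

Among the measured compounds shown here, no measured step of this kind exists among the three compounds, so the direction has to be estimated. Compound 3 carries a small alkyl group on the same kind of ring position, yet its other ring differs, so it does not settle the matter. The expectation is a modest drop in the tolerated concentration, a step of a 1.9-fold lower number from compound 2 to compound 4 (0.28 log units; within the scatter) in this assay, which is not far outside the usual scatter.

Compound 4 is therefore expected to show 12000 nM in this assay, with a range from 3000 nM to 40000 nM.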

Compound 4, half-maximal cytotoxic concentration: 31000 nM
Estimate against measurement, compound 4: 2.6-fold (0.41 log units) below; low and high end bracket the measured number.
By their numbers in this assay, from the lowest: compounds 2 and 4 (each within the scatter of the next); then compound 3. At a limit, below all of these: compound 1.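

In this assay, among the compounds shown here, the first step that can be read at this position is a 1.3-fold higher number from compound 2 to compound 4 (0.13 log units; within the scatter), so compound 2 and compound 4 cannot be told apart. Ethyl in place of hydrogen on this aromatic carbon, ortho to the (3-methylbut-2-en-1-yl)oxy group and para to the (1,3-thiazol-2-yl)amino group, thus gives no change in tolerated concentration that stands out from repeated measurement, a reading the earlier compounds could not give, as no two of them differed in one place only. Nothing measured here bears on a cause for this result.

The compounds shown leave open whether this tolerance holds for other groups at the same position, such as a longer chain, an amine or a carboxylic acid, as only hydrogen and ethyl can be compared here. For the compounds shown here, they also leave open whether ethyl at this position would behave the same way on the core of compound 3 or the core of compound 1, where the other ring differs from the one in compound 2 and compound 4.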